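The compounds below may be only part of what the source reports. "The series", "measured", "known", "first", "only" and "open" are said of these compounds alone.

In a functional assay on SW1990 cells (Homo sapiens) for cytotoxicity, read by MTT assay, with a stated time of 48 h, in the presence of a further agent that is not named here (on this read-out higher numbers stand for weaker inhibition and lower numbers for stronger inhibition), compound 1 `O=C(c1ccc2cccc(OCc3ccc(B(O)O)cc3)c2n1)N1CCC(Oc2no[n+]([O-])c2S(=O)(=O)c2ccccc2)CC1` gives 18700 nM and compound 2 `O=C(NCCCOc1no[n+]([O-])c1S(=O)(=O)c1ccccc1)c1ccc2cccc(OCc3ccc(B(O)O)cc3)c2n1` gives 15400 nM while compound 3 `O=C(NCCCOc1no[n+]([O-])c1S(=O)(=O)c1ccccc1)c1ccc2cccc(O)c2n1` gives 12100 nM as its value, so compound 2 sits within the scatter of both others. Compound 4 `CC1(C)OB(c2ccc(COc3cccc4ccc(C(=O)NCCCOc5no[n+]([O-])c5S(=O)(=O)c5ccccc5)nc34)cc2)OC1(C)C` is still unmeasured and differs from compound 2 by a group of 9 heavy atoms (6 carbon, 1 boron, 2 oxygen; one five-membered non-aromatic ring with 3 hetero atoms) in place of a group of 3 heavy atoms (1 boron, 2 oxygen; no ring), on an aromatic carbon in a position para to a large group. For the measured compounds named here, the only measured step touching this part of the structure is a 1.3-fold lower number from compound 2 to compound 3 (0.10 log units; within the scatter) and it stays within the scatter although the whole boron-bearing group is lost. No step beyond the scatter is therefore expected in this assay for this change. The estimated step (a 1.0-fold lower number from compound 2 to compound 4 (0.01 log units; within the scatter)) lies within the scatter. Compound 4 is estimated at 15000 nM (expected range 8000 nM to 28000 nM).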

Compound 4, half-maximal inhibitory concentration: 20800 nM
Compound 4: middle estimate off by 1.4-fold (0.14 log units), on the low side; low and high end bracket the measured number.
By their numbers in this assay, from the lowest: compounds 3, 2, 1 and 4 (each within the scatter of the next).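

In this assay, the earlier step removed the whole boron-bearing group, whereas this one keeps the boron and replaces only the group of 3 heavy atoms with the five-membered ring group of 9 heavy atoms, giving a 1.4-fold higher number from compound 2 to compound 4 (0.13 log units; within the scatter). At this aromatic carbon, the larger group with 0 hydrogen-bond donors therefore gives no step beyond the scatter. Nothing available explains this result.

Still open, on these data alone, is whether a carboxylic acid or an amine on this aromatic carbon, in place of the boron group, would give a step beyond the scatter. Also open, as far as these compounds go, is whether the five-membered ring group gives a similar result on the core of compound 1.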